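Trimming the amide away: expectations for compound 4

This account rests on a few compounds, and the source may have more. Where it says the series, first, only, none or still open, it means among the compounds named here.

Compound 3 `COc1ccc(S(=O)(=O)N2CCc3cccc(NC(C)=O)c32)cc1` gives 61 nM in a functional assay on MKN-45 cells (Homo sapiens) for cytotoxicity (a higher number here means a weaker inhibitor, a lower number a stronger inhibitor), the highest number among the three measured compounds and therefore the weakest inhibitor of them. Compound 1 `COc1ccc(S(=O)(=O)N2CCc3cccc(NC(=O)c4ccncc4)c32)cc1` gives 8.8 nM and compound 2 `COc1ccc(S(=O)(=O)N2CCc3cccc(NC(=O)c4ccco4)c32)cc1` gives 10.7 nM. Those two sit within the scatter of each other: a 1.2-fold higher number from compound 1 to compound 2 (0.08 log units; within the scatter). Compound 4 `COc1ccc(S(=O)(=O)N2CCc3cccc(N)c32)cc1` differs from compound 3 by hydrogen in place of acetyl on a nitrogen on an aromatic ring. Within the data shown here, no measured step covers this exact change. The nearest guides are a 6.9-fold higher number from compound 1 to compound 3 (0.84 log units; beyond the scatter) and a 5.7-fold higher number from compound 2 to compound 3 (0.76 log units; beyond the scatter), where shrinking the group on the carbonyl carbon raised the number modestly. Removing the acetyl altogether is expected to continue that direction, so compound 4 is estimated to show a 3.3-fold higher number from compound 3 to compound 4 (0.52 log units; beyond the scatter), landing near 200 nM with a range of 60 nM to 700 nM.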

Compound 4, half-maximal inhibitory concentration: 1200 nM
Compound 4: the middle estimate sits 6.0-fold (0.78 log units) below what was measured; the whole stated range lies below it.
By their numbers in this assay, from the lowest: compounds 1 and 2 (each within the scatter of the next); then compound 3; then compound 4.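

In this assay, the group on this nitrogen matters far more than the amides alone suggested: even the small acetyl carries much of the effect, since removing it gives a 20-fold higher number from compound 3 to compound 4 (1.29 log units; beyond the scatter). Against the two larger amides, the bare amino group gives a 110-fold higher number from compound 2 to compound 4 (2.05 log units; beyond the scatter) and a 140-fold higher number from compound 1 to compound 4 (2.13 log units; beyond the scatter). Nothing shown here explains this loss.

From the compounds shown here alone, it remains open whether the carbonyl itself is needed. An ethyl or a methanesulfonyl group on this nitrogen would separate the carbonyl from the mere presence of a substituent.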